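Isobutyl replaces 3-chlorophenyl on the shared core

This account rests on a few compounds, and the source may have more. Where it says the series, first, only, none or still open, it means among the compounds named here.

Compound 1, with structure `O=C(O)c1cccc(Cc2c(-c3cccc(Cl)c3)nn3cc(Cl)ccc23)n1`, is the weakest of the three measured analogues in a functional assay on cells for antagonist activity at prostaglandin E2 receptor EP1 subtype (Rattus norvegicus), read by fluorescence and calcium flux, with a stated time of 60 s (a higher number here means a weaker inhibitor, a lower number a stronger inhibitor), where compound 1 gives 480 nM. Compound 2, `O=C(O)c1cccc(Cc2c(-c3ccoc3)nn3cc(Cl)ccc23)n1`, gives 130 nM in this assay, and compound 3, `CC(C)(C)c1nn2cc(Cl)ccc2c1Cc1cccc(C(=O)O)n1`, gives 48 nM. The two steps away from compound 1 both lower the number: a 3.7-fold lower number from compound 1 to compound 2 (0.57 log units; beyond the scatter) and a 10-fold lower number from compound 1 to compound 3 (1.00 log units; beyond the scatter). Between the two replacements, a 2.7-fold lower number from compound 2 to compound 3 (0.43 log units; beyond the scatter).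

Compound 4, `CC(C)Cc1nn2cc(Cl)ccc2c1Cc1cccc(C(=O)O)n1`, is not yet measured. It differs from compound 1 by isobutyl in place of 3-chlorophenyl on an aromatic carbon. Within the data shown here, the closest precedent is the step to compound 3, which also puts a branched alkyl group at this aromatic carbon next to the ring nitrogen. Compound 4 is therefore expected to improve on compound 1 by a step of about a 6.9-fold lower number from compound 1 to compound 4 (0.84 log units; beyond the scatter) in this assay, in the same direction as the step to compound 3 and of roughly similar size. The estimate for compound 4 in this assay is 70 nM, with a range of 25 nM to 200 nM.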

Compound 4, half-maximal inhibitory concentration: 200 nM
For compound 4 the middle estimate is 2.9-fold (0.46 log units) below the measured one; the measured number falls inside the stated range.
By their numbers in this assay, from the lowest: compound 3; then compounds 2 and 4 (each within the scatter of the next); then compound 1.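

Isobutyl still lowers the number relative to 3-chlorophenyl in this assay (a 2.4-fold lower number from compound 1 to compound 4 (0.38 log units; beyond the scatter)), so the earlier gain on leaving the aryl ring is seen with a second alkyl group, but the two alkyl groups are not interchangeable at this aromatic carbon (a 4.2-fold higher number from compound 3 to compound 4 (0.62 log units; beyond the scatter)). Isobutyl and furan-3-yl, by contrast, cannot be told apart here (a 1.5-fold higher number from compound 2 to compound 4 (0.19 log units; within the scatter)), so a ring is not needed to reach this level, and having an alkyl group in place of a ring does not by itself give the result seen with tert-butyl. Nothing shown here explains why tert-butyl and isobutyl differ.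

The compounds shown leave open how cyclopropyl or a longer chain such as neopentyl would compare with tert-butyl at this carbon. They also leave open whether a ring bearing an amine would fit the same order.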